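A few compounds are considered here, and "the series" means these few. Any claim that something is new, unique, unknown or untested is made for them only; others in the source may bear on it.

Of the compounds shown here, three of one shared core have been measured in an assay on isolated protein for inhibition of DNA topoisomerase 1 (Homo sapiens), with a stated time of 30 min, tested at 100 uM; a lower number here means a weaker effect, a higher number a stronger effect of the compound at the concentration tested. Compound 1 `Oc1cccc(-c2cc(-c3ccccc3)cc(-c3ccco3)n2)c1` gives 10.2% in this assay. Compound 2 `Oc1ccc(-c2cc(-c3ccccc3)cc(-c3ccc(O)cc3)n2)cc1` gives 0.3% in this assay. Compound 3 `Oc1cccc(-c2cc(-c3ccccc3)nc(-c3cccs3)c2)c1` gives 9.1% in this assay. On these numbers compound 3 sits second highest of the three, its nearest neighbour being compound 1, with a gap that lies within the scatter, and its furthest compound 2, with a gap that also lies within the scatter; no pair of these compounds is separated by more than the scatter.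

Compound 4 `Oc1cccc(-c2cc(-c3ccccc3)nc(-c3ccco3)c2)c1` has not yet been measured. It differs from compound 3 in one place: furan-2-yl in place of thiophen-2-yl on an aromatic carbon. For the measured compounds named here, no two measured compounds differ in only one place, so this step has no measured precedent, and all three measured numbers sit in the same low band. On that basis the expected a number 0.1 percentage points lower from compound 3 to compound 4 (within the scatter) amounts to none beyond the scatter. Compound 4 is accordingly estimated at 9% in this assay, within a range from 0% to 20%.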

Compound 4, a percentage reported as inhibition, at one concentration (the size of the read-out at that concentration, not a potency): 48.8%
Compound 4: the middle estimate sits 39.8 percentage points below what was measured; measured number above the stated range.
By their numbers in this assay, from the lowest: compounds 2, 3 and 1 (each within the scatter of the next); then compound 4.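

In this assay, putting furan-2-yl in place of thiophen-2-yl on the aromatic carbon next to the ring nitrogen gives a number 39.7 percentage points higher from compound 3 to compound 4 (beyond the scatter), the only one-place step among these compounds and one that lies beyond the scatter. This position therefore does not treat the two five-membered aromatic rings alike, although the groups match in every count of heavy atoms, hydrogen-bond donors and hydrogen-bond acceptors and differ in one ring atom, oxygen for sulfur. Nothing available here bears on what lies behind this step.

This single pair leaves open whether the same exchange would have a similar effect if the 3-hydroxyphenyl or phenyl group were replaced. It also leaves open how this position would respond to a plain phenyl, an amine or a carboxylic acid in place of furan-2-yl.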